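Furan-3-yl replaces the oxadiazole at the solubility limit

The source may hold more compounds than are shown below. What is called first, only, known or untested is meant among the compounds shown, and "the series" means these compounds.

Compound 1 `Cc1cc(-c2ccc(N3C(=O)C(O)=C(C(=O)C(C)(C)C)C3c3ccccc3OCCO)cc2)on1`: > 50000 nM
Compound 2 `Cc1nc(-c2ccc(N3C(=O)C(O)=C(C(=O)C(C)(C)C)C3c3ccccc3OCCO)cc2)no1`: > 50000 nM

In a physicochemical assay for solubility, in phosphate buffer, at pH 6.8 (a lower number here means a less soluble compound, a higher number a more soluble compound), compound 2 gives > 50000 nM, which is a limit and not a number. Within the data shown here, the series so far offers only (the limit of > 50000 nM in this assay, at which 2 of the 2 values shown sit). Compound 3 `CC(C)(C)C(=O)C1=C(O)C(=O)N(c2ccc(-c3ccoc3)cc2)C1c1ccccc1OCCO` differs from compound 2 by furan-3-yl in place of 5-methyl-1,2,4-oxadiazol-3-yl on an aromatic carbon. Among the measured compounds shown here, the one measured step that bears on this exchange of five-membered aromatic rings is a step that the two limits leave unreadable from compound 1 to compound 2, so it offers no size to carry over. No step beyond the scatter is therefore expected in this assay, and no direction can be named. The expected step is a number no higher from compound 2 to compound 3 (the limit leaves the size open). The estimate for compound 3 is 50000 nM, with an expected range of 20000 nM to 100000 nM.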

Compound 3, solubility: > 50000 nM
Compound 3 ended at the assay's limit; the forecaster's own chance of this, stated with the estimate: 60%; the middle value sits exactly at the limit.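

Compound 1, compound 2 and compound 3 all stand at a limit, not a number, in this assay, so no step between them can be read: the limit of > 50000 nM in this assay, at which 3 of the 3 values shown sit.

The compounds shown leave open whether exchanging these five-membered aromatic rings changes the read-out at all.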